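The source may hold more compounds than are shown below. What is called first, only, known or untested is meant among the compounds shown, and "the series" means these compounds.

Of the compounds shown here, three sharing a common core have been measured in a functional assay on NCI-H460 cells (Homo sapiens) for antiproliferative activity, with a stated time of 72 h; on this read-out lower numbers stand for stronger inhibition and higher numbers for weaker inhibition. Compound 1 (`C=C[C@@H]1C[C@@H](Cc2ccc(OC)c(O)c2)[C@H]2C(=O)C=CC(=C)[C@H]21`) gives 14.5 nM. Compound 2 (`C=C1C=CC(=O)[C@@H]2[C@H](Cc3ccc(OCOC)cc3)CC[C@H]12`) gives 226 nM. Compound 3 (`C=C1C=CC(=O)[C@@H]2[C@H](Cc3ccc(F)c(F)c3)CC[C@H]12`) gives 511 nM, the highest of the three numbers and so the weakest of the set, with compound 2 its nearest neighbour and compound 1 the furthest away, both gaps lying beyond the scatter.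

The next compound, compound 4 (`C=C1C=CC(=O)[C@@H]2[C@H](Cc3ccc(O)c(F)c3)CC[C@H]12`), departs from compound 3 at a single place: hydroxy in place of fluoro on an aromatic carbon. This is hydroxy in place of fluoro on an aromatic carbon, ortho to a fluoro group and para to a large group.

Going by the values given here, no measured pair differs in only one place, so the data offer no direct precedent for this change. Among the compounds with values here, the nearest hint is compound 1, the only measured compound with a hydroxy group on its aromatic ring, at 14.5 nM, although it differs from compound 3 in other places too. In this assay a moderate step towards a lower number, beyond the scatter, is therefore expected, though with wide uncertainty. The expected change is a 3.4-fold lower number from compound 3 to compound 4 (0.53 log units; beyond the scatter). For compound 4 the estimated value is 150 nM, with an expected range from 40 nM to 550 nM.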

Compound 4, half-maximal inhibitory concentration: 229 nM
Beside the measured number, compound 4's estimate is 1.5-fold (0.18 log units) below it; low and high end bracket the measured number.
By their numbers in this assay, from the lowest: compound 1; then compounds 2 and 4 (each within the scatter of the next); then compound 3.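

In this assay, going by these compounds alone, a 2.2-fold lower number from compound 3 to compound 4 (0.35 log units; beyond the scatter) gives the first direct reading of a change at a single place in this set. Compound 1 had offered only an indirect hint, since it differs from compound 3 in other places too, whereas this step shows that hydroxy in place of fluoro, on an aromatic carbon ortho to a fluoro group and para to a large group, by itself gives a modest move towards stronger inhibition. The exchange adds a hydrogen-bond donor and a hydrogen-bond acceptor where the fluoro counted neither, yet no measurement here says what accounts for the step.

From the compounds shown here alone, it remains open whether an amine or a carboxylic acid on this same aromatic carbon would carry the number further down, stop at a similar level or reverse the step. Also open, going by these compounds, is whether hydroxy in place of fluoro would give a step of similar size if the neighbouring fluoro group were replaced by hydrogen or a chloro group, or if the exchange were made on the core of compound 1.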